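From Compound 2 to Compound 3: Adding an Ethyl Group

This account rests on a few compounds, and the source may have more. Where it says the series, first, only, none or still open, it means among the compounds named here.

In a functional assay on P388 cells (Mus musculus) for cytotoxicity (on this read-out higher numbers stand for weaker inhibition and lower numbers for stronger inhibition), compound 1 (`C[C@@H]1NC(=O)[C@@H](C)NC(=O)[C@@H]2Cc3ccc(O)c(c3)Oc3ccc(cc3)C[C@@H](C(=O)N2C)N(C)C(=O)[C@H](C)NC(=O)[C@H](Cc2ccccc2)N(C)C1=O`) gives 42.7 nM and compound 2 (`COc1ccc2cc1Oc1ccc(cc1)C[C@H]1C(=O)N(C)[C@@H](C2)C(=O)N[C@H](C)C(=O)N[C@@H](C)C(=O)N(C)[C@@H](Cc2ccccc2)C(=O)N[C@@H](C)C(=O)N1C`) gives 295 nM as the higher of the two numbers. Compound 3 (`CCc1ccc(C[C@H]2C(=O)N[C@@H](C)C(=O)N(C)[C@H]3Cc4ccc(cc4)Oc4cc(ccc4OC)C[C@@H](C(=O)N[C@H](C)C(=O)N[C@@H](C)C(=O)N2C)N(C)C3=O)cc1`) is still unmeasured. It differs from compound 2 by ethyl in place of hydrogen on an aromatic carbon, para to a large group, so that benzyl becomes 4-ethylbenzyl. Among the measured compounds shown here, the only measured step (a 6.9-fold higher number from compound 1 to compound 2 (0.84 log units; beyond the scatter)) came with methyl in place of hydrogen on an oxygen on an aromatic ring. That change lies at a different place, so it is only a rough guide. On this single precedent, a modest rise in the number in this assay is expected, though the direction remains uncertain. The estimate means an expected step (a 2.2-fold higher number from compound 2 to compound 3 (0.34 log units; beyond the scatter)) of modest size. For compound 3 the estimated value is 650 nM with a range from 180 nM to 2300 nM as expected bounds.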

Compound 3, half-maximal inhibitory concentration: 9.33 nM
Compound 3: middle estimate off by 70-fold (1.84 log units), on the high side; measured number outside the range, below it.
By their numbers in this assay, from the lowest: compound 3; then compound 1; then compound 2.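

In this assay, ethyl in place of hydrogen on an aromatic carbon, para to a large group, turns benzyl into 4-ethylbenzyl and brings a 32-fold lower number from compound 2 to compound 3 (1.50 log units; beyond the scatter), a large step that shows the number responds strongly to a change at this position. Among the compounds shown here, the only earlier step, a 6.9-fold higher number from compound 1 to compound 2 (0.84 log units; beyond the scatter), lay at a different place, came with methyl in place of hydrogen on an oxygen on an aromatic ring, and ran in the opposite direction, so it could not show this. No measurement is at hand that explains the step.

The compounds shown leave open whether a methyl, a longer propyl chain, an amine or a carboxylic acid at this position would act as ethyl does. They also leave open whether 4-ethylbenzyl would bring a similar step when the aromatic oxygen carries hydrogen rather than methyl.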